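A few compounds are considered here, and "the series" means these few. Any claim that something is new, unique, unknown or untested is made for them only; others in the source may bear on it.

Of the compounds shown here, three that share one core have been measured in a functional assay on the whole organism with Rattus norvegicus as the target; a higher number here means that more compound is needed for the effect, a lower number that less compound is needed. Compound 1 `CC(C)(C)Oc1ccc2nc(N)sc2c1` gives only a limit, > 10 mg/kg, so no number is known for it. Compound 2 `Nc1nc2ccc(SC(F)(F)F)cc2s1` gives 8 mg/kg, and compound 3 `CCCn1c(=N)sc2cc(OC(F)(F)F)ccc21` gives 4.5 mg/kg; the gap between these two numbers lies within the usual scatter, so neither can be set ahead of the other. Among the compounds with values here, the one measured step that changes a single place shows an at least 1.2-fold lower number from compound 1 to compound 2 (0.09 log units; that floor lies within the scatter), a swap of (trifluoromethyl)sulfanyl for tert-butoxy on an aromatic carbon. That step starts from the limit of > 10 mg/kg in this assay, at which 1 of the 3 values shown sits, and therefore sets only a floor.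

Compound 4 `CSCCn1c(=N)sc2cc(OC(F)(F)F)ccc21` has not yet been measured. It differs from compound 3 in one place: methylsulfanyl in place of methyl on a saturated chain carbon, two bonds along the chain from an aromatic nitrogen. Cut one bond further out, the chain on the aromatic nitrogen goes from propyl to 2-(methylsulfanyl)ethyl. Within the data shown here, no measured step touches this chain; the only measured step swaps a group on an aromatic carbon and so says nothing about what a change on the chain does. Among the measured compounds shown here, with no step to lean on, the expected change in this assay is no change at the digits printed from compound 3 to compound 4 (within the scatter), that is, none beyond the scatter. Compound 4 is therefore estimated to give 4.5 mg/kg, with a range from 2 mg/kg to 10 mg/kg.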

Compound 4, dose for half-maximal effect: 1 mg/kg
Compound 4: middle estimate off by 4.5-fold (0.65 log units), on the high side, outside the stated range (below it).
By their numbers in this assay, from the lowest: compound 4; then compounds 3 and 2 (each within the scatter of the next). At a limit, above all of these: compound 1.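

In this assay, methylsulfanyl in place of methyl on a saturated chain carbon, two bonds along the chain from an aromatic nitrogen, gives a 4.5-fold lower number from compound 3 to compound 4 (0.65 log units; beyond the scatter). Within the data shown here, this is the first measured change on this chain, and it shows that the number responds to what sits there, which the earlier step, made on an aromatic carbon and starting from a limit, could not show. The step is also the first here that is both a full number and beyond the scatter, but nothing measured on these compounds accounts for why the number falls.

Among these compounds, the single step leaves open whether the lower number goes with the sulfur atom itself or simply with the change from propyl to 2-(methylsulfanyl)ethyl, a question that a chain ending in a methoxy group, an amine or a longer sulfur-bearing chain at the same place would help to settle. It also leaves open whether the same change on the chain would give a similar step with trifluoromethylsulfanyl instead of the trifluoromethoxy group on the aromatic carbon.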